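From Methyl to Methoxy: A Step Without Numbers

A few compounds are considered here, and "the series" means these few. Any claim that something is new, unique, unknown or untested is made for them only; others in the source may bear on it.

Compound 1 `Cc1ccc(/C=C(/C#N)C(=O)c2ccc[nH]2)cc1`: < 10000 nM
Compound 2 `N#C/C(=C/c1ccc(O)cc1)C(=O)c1ccc[nH]1`: < 10000 nM

In a functional assay on A-431 cells (Homo sapiens) for cytotoxicity, read by MTT assay, with a stated time of 72 h (a lower number here means a stronger inhibitor of growth, a higher number a weaker inhibitor of growth), compound 1 gives < 10000 nM, which is a limit and not a number. Compound 2 gives < 10000 nM, which is also a limit. Both measurements therefore stand at the limit of < 10000 nM in this assay, at which 2 of the 2 values shown sit. Compound 3 `COc1ccc(/C=C(/C#N)C(=O)c2ccc[nH]2)cc1` has methoxy in place of methyl on an aromatic carbon, para to a large group: methoxy in place of methyl on an aromatic carbon. The nearest measured change is a step that the two limits leave unreadable from compound 1 to compound 2, which also replaces that methyl, so it offers no size or direction to carry over, and no clear shift is expected in this assay. The estimated change is a step that the limit leaves unreadable from compound 1 to compound 3. For compound 3 the expected value is 3000 nM, with an estimated range from 600 nM to 10000 nM.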

Compound 3, concentration for 50% growth inhibition: 13000 nM
Compound 3: the middle estimate sits 4.3-fold (0.64 log units) below what was measured; measured number above the stated range.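

In this assay, within the data shown here, compound 3 gives 13000 nM, the first plain number for a group at this place on the ring. Compound 1 and compound 2 carry only limits. Methoxy in place of methyl gives an at least 1.3-fold higher number from compound 1 to compound 3 (0.11 log units; that floor lies within the scatter), and methyl in place of hydrogen on the oxygen gives an at least 1.3-fold higher number from compound 2 to compound 3 (0.11 log units; that floor lies within the scatter). Both steps give only a floor, so their true sizes cannot be read. On these data alone, how far compound 1 and compound 2 really lie from compound 3 stays open, as does what an amine or a carboxylic acid would give here.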